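Swapping propyl for 3-chlorophenyl on the benzimidazole-like core

The compounds below may be only part of what the source reports. "The series", "measured", "known", "first", "only" and "open" are said of these compounds alone.

Compound 3 `CCCCn1c(CN2CCN(C(=O)C3CC3)CC2)nc2ccccc21` gives 18.2% in an assay on isolated protein for inhibition of aldehyde dehydrogenase 1A1 (Homo sapiens), read by spectrophotometry, tested at 10 uM; a higher number here means more inhibition at the concentration tested (going by the name of the read-out), a lower number less inhibition. Compound 1 `O=C(C1CC1)N1CCN(Cc2nc3ccccc3n2Cc2cccc(F)c2)CC1` gives 27.2%, and compound 2 `Cc1ccc(Cn2c(CN3CCN(C(=O)C4CC4)CC3)nc3ccccc32)cc1` gives 51.5%. The step of a number 9 percentage points lower from compound 1 to compound 3 (within the scatter) lies within the scatter, whereas the step of a number 33.3 percentage points lower from compound 2 to compound 3 (beyond the scatter) is large and beyond it, so only the aryl group bearing a methyl has so far separated itself from the propyl chain.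

Compound 4 `O=C(C1CC1)N1CCN(Cc2nc3ccccc3n2Cc2cccc(Cl)c2)CC1` differs from compound 3 as follows: 3-chlorophenyl in place of propyl on a saturated chain carbon bound to an aromatic nitrogen. The closest guide is the reversed step a number 9 percentage points lower from compound 1 to compound 3 (within the scatter), since 3-chlorophenyl and 3-fluorophenyl share the same pattern of substitution; the step of a number 33.3 percentage points lower from compound 2 to compound 3 (beyond the scatter) shows the upper end of what an aryl group has achieved here. A modest rise is therefore expected, likely near or just beyond the scatter, as a number 11.8 percentage points higher from compound 3 to compound 4 (beyond the scatter). Compound 4 is estimated at 30% in this assay, within a range of 12% to 52%.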

Compound 4, a percentage reported as inhibition, at one concentration (the size of the read-out at that concentration, not a potency): 71.6%
Compound 4: middle estimate off by 41.6 percentage points, on the low side; the measured number lies above the stated range.
By their numbers in this assay, from the lowest: compounds 3 and 1 (each within the scatter of the next); then compound 2; then compound 4.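

In this assay, among these compounds, the halogen on the aryl ring proves decisive at this position: the single change of chloro in place of fluoro on an aromatic carbon gives a number 44.4 percentage points higher from compound 1 to compound 4 (beyond the scatter). An aryl group on the saturated chain carbon bound to an aromatic nitrogen therefore does not in itself lift the number, since 3-fluorophenyl stays within the scatter of propyl while 3-chlorophenyl gives a number 53.4 percentage points higher from compound 3 to compound 4 (beyond the scatter) and also exceeds 4-methylphenyl with a number 20.1 percentage points higher from compound 2 to compound 4 (beyond the scatter). Nothing shown here explains why these close aryl groups part so widely.

The step from compound 2 to compound 4 changes both the substituent and its place on the ring, so the two effects remain unseparated, and 3-methylphenyl and 4-chlorophenyl would be needed to tell them apart. As far as these compounds go, it also remains open whether 3-bromophenyl would follow 3-chlorophenyl.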